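The source may report more compounds than this note shows. Statements on the series, on what has been measured and on what is new or still open speak of the compounds shown alone.

Values in an ADME assay on CEM-SS cells (Homo sapiens) for cytotoxicity, read by XTT assay; on this read-out higher numbers stand for lower toxicity in this test and lower numbers for higher toxicity in this test:

Compound 1 `CN(O)C(=O)c1cc2ccn(Cc3ccc(F)cc3)c2cn1`: 135000 nM.
Compound 2 `CN(O)C(=O)c1cc2c(CN3CCNC(=O)C3)cn(Cc3ccc(F)cc3)c2cn1`: > 100000 nM, a limit of the assay.
Compound 3 `COCc1cn(Cc2ccc(F)cc2)c2cnc(C(=O)N(C)O)cc12`: 266000 nM.

Within the data shown here, compound 3 has only one numeric neighbour, and the gap to it is small: a 2.0-fold higher number from compound 1 to compound 3 (0.29 log units; within the scatter). Compound 2 stands at a limit: the limit of > 100000 nM in this assay, at which 1 of the 3 values shown sits.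

The next compound is compound 4 `CC(C)NC(=O)c1cn(Cc2ccc(F)cc2)c2cnc(C(=O)N(C)O)cc12`, with isopropylcarbamoyl in place of methoxymethyl on an aromatic carbon. This carbon belongs to the five-membered aromatic ring with 1 nitrogen, two ring bonds from the ring nitrogen.

Two measured steps change this same carbon, both starting from hydrogen. Methoxymethyl gives a 2.0-fold higher number from compound 1 to compound 3 (0.29 log units; within the scatter), so this substitution moved the number by no more than the scatter. The (3-oxopiperazin-1-yl)methyl group gives a step that the limit leaves unreadable from compound 1 to compound 2, which adds no size. Exchanging one of these groups for another gives a step that the limit leaves unreadable from compound 2 to compound 3, which is equally silent.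

Among the measured compounds shown here, the only readable evidence is therefore the step to compound 3, and no step beyond the scatter is expected. The expected change is a 1.6-fold lower number from compound 3 to compound 4 (0.19 log units; within the scatter). The estimate for compound 4 is 170000 nM, with an expected range from 60000 nM to 350000 nM.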

Compound 4, half-maximal cytotoxic concentration: > 100000 nM
Compound 4 gave a limit, no number (the forecaster's own chance of this, stated with the estimate: 35%); the middle value is on the limit's open side.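

In this assay compound 4 gives > 100000 nM, a limit of the assay and not a number, so its steps from compound 1, compound 2 and compound 3 cannot be read. Compound 4 joins compound 2 here: the limit of > 100000 nM in this assay, at which 2 of the 4 values shown sit.

The compounds shown leave open how far isopropylcarbamoyl on this aromatic carbon shifts the read-out relative to hydrogen or methoxymethyl.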